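Methyl in place of bromo: notes on the next step

This account rests on a few compounds, and the source may have more. Where it says the series, first, only, none or still open, it means among the compounds named here.

Among the compounds with values here, the series so far rests on very little data in a functional assay on HepG2 cells (Homo sapiens) for cytotoxicity, read by MTT assay, with a stated time of 72 h; a lower number here means a stronger inhibitor, a higher number a weaker inhibitor. For compound 1 (`CNC(=O)c1cc(Oc2ccc(C(=O)/C=C/c3ccco3)cc2)ccn1`) the entry reads "not determined" (no result reported), so it offers no point of comparison. Within the data shown here, compound 2 (`CNC(=O)c1cc(Oc2ccc(/C=C/C(=O)c3ccc(Br)cc3)cc2)ccn1`) gives 22000 nM as the only number available, which means its standing cannot yet be ranked against any other compound.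

Compound 3 (`CNC(=O)c1cc(Oc2ccc(/C=C/C(=O)c3ccc(C)cc3)cc2)ccn1`) is the next to be read. Its difference from compound 2 is (methyl in place of bromo on an aromatic carbon): methyl in place of bromo on an aromatic carbon, para to a large group. The cut one bond further out reads 4-bromophenyl to 4-methylphenyl.

Among the measured compounds shown here, the series holds no measured step for this exchange, so neither its size nor its direction can be taken from the data. For the measured compounds named here, the sole anchor is compound 2 at 22000 nM, and no shift beyond the usual scatter is expected in either direction. The expected change (a 1.1-fold higher number from compound 2 to compound 3 (0.06 log units; within the scatter)) is therefore small. In this assay the estimated value for compound 3 is 25000 nM, with an expected range (10000 nM to 60000 nM).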

Compound 3, half-maximal inhibitory concentration: > 50000 nM
Compound 3: only a limit was reported; the forecaster's own chance of this, stated with the estimate: 15%; at least 2.0-fold (0.30 log units) between middle value and limit.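

Within the data shown here, this is the first measured step, and it concerns the substituent on the aromatic carbon para to a large group. In this assay, compound 3 gives > 50000 nM, which is a limit of the assay and not a number. The exchange of bromo for methyl at this position gives an at least 2.2-fold higher number from compound 2 to compound 3 (0.35 log units; beyond the scatter), so the 4-bromophenyl to 4-methylphenyl change has a direction beyond the scatter, while its full size remains unfixed, and the reading for the 4-methylphenyl form rests on this bound: the limit of > 50000 nM in this assay, at which 1 of the 3 values shown sits.

The compounds shown leave open whether the number of compound 2 reflects something particular to bromo or whether other substituents at this carbon would give a lower number, as only bromo and methyl can be compared here and a single step fixes no trend. An amine, a carboxylic acid or a longer chain such as propyl at the same carbon would show whether the step from compound 2 holds beyond this one pair, and the entry for compound 1 adds nothing to that question.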